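Replacing Methoxy With Pyridin-4-yl: An Expected Drop

This account rests on a few compounds, and the source may have more. Where it says the series, first, only, none or still open, it means among the compounds named here.

Compound 1 `COc1ccc2c(c1)C(n1ccccc1=O)=CC(C)(C)O2` is the more potent of the two measured compounds: in a functional assay (aorta) with Rattus norvegicus as the target (a higher number here means a more potent compound, by a factor of ten per unit of this negative logarithm, a lower number a less potent compound), compound 1 gives 6.55, while compound 2 `CC1(C)C=C(n2ccccc2=O)c2cc(OC(=O)Nc3ccc(F)cc3)ccc2O1` gives 5.3. Going by the values given here, the one measured step, a number 1.25 log units lower from compound 1 to compound 2 (beyond the scatter), exchanged the methyl on the aromatic oxygen for a larger group and lowered potency well beyond the scatter. Compound 3 `CC1(C)C=C(n2ccccc2=O)c2cc(-c3ccncc3)ccc2O1` differs from compound 1 in one place: pyridin-4-yl in place of methoxy on an aromatic carbon. Among the compounds with values here, only that single step bears on this change, and it points downward, so a loss beyond the scatter is expected, estimated as a number 0.75 log units lower from compound 1 to compound 3 (beyond the scatter). Compound 3 is therefore expected to give about 5.8, within a range from 5 to 6.6.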

Compound 3, logarithm of the reciprocal of the active concentration, log(1/C): 6.68
Estimate against measurement, compound 3: 0.88 log units below; the measured number lies above the stated range.
By their numbers in this assay, from the lowest: compound 2; then compounds 1 and 3 (each within the scatter of the next).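

Pyridin-4-yl brings a ring and more heavy atoms than methoxy, yet in this assay this change gives a number 0.13 log units higher from compound 1 to compound 3 (within the scatter). Going by these compounds alone, a larger group at this aromatic carbon therefore need not lower potency, which the single earlier step could not show. Compound 2 now stands as the case with a loss, and compound 3 as the case without one. Going by these compounds, whether a plain phenyl ring or a simple amine at this place would match pyridin-4-yl stays open. Nothing measured here explains why these two replacements differ.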